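Removing the Indole Chloro from the Sulfone Analogue

This account rests on a few compounds, and the source may have more. Where it says the series, first, only, none or still open, it means among the compounds named here.

Compound 1 `Cc1ccc(S/C(=C/c2c[nH]c3ccccc23)C(=O)c2ccc(Br)cc2)cc1`: 10000 nM
Compound 2 `Cc1ccc(S/C(=C/c2c[nH]c3ccc(Cl)cc23)C(=O)c2ccc(Br)cc2)cc1`: 1000 nM
Compound 3 `Cc1ccc(S(=O)(=O)/C(=C/c2c[nH]c3ccc(Cl)cc23)C(=O)c2ccc(Br)cc2)cc1`: 10000 nM

All three were tested in a functional assay on DU-145 cells (Homo sapiens) for inhibition, read by trypan blue exclusion, with a stated time of 96 h; on this read-out lower numbers stand for stronger inhibition of growth and higher numbers for weaker inhibition of growth. Compound 2 gives the lowest number of the three. From compound 2 to compound 1 the change is hydrogen in place of chloro on an aromatic carbon, and the step is a 10-fold higher number from compound 2 to compound 1 (1.00 log units; beyond the scatter). Compound 3 carries a different core than compound 2, the difference being ((4-methylphenyl)sulfonyl in place of (4-methylphenyl)sulfanyl on a double-bonded chain carbon bound to a carbonyl carbon and a double-bonded chain carbon), and the step is a 10-fold higher number from compound 2 to compound 3 (1.00 log units; beyond the scatter). Compound 3 and compound 1 are level at the digits given, so no order can be read between them.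

Compound 4 `Cc1ccc(S(=O)(=O)/C(=C/c2c[nH]c3ccccc23)C(=O)c2ccc(Br)cc2)cc1` has not yet been measured in this assay. It differs from compound 3 by hydrogen in place of chloro on an aromatic carbon. This is the same change, at the same place, as that made from compound 2 to compound 1; the two cores differ in the way given just above. Because compound 3 already sits at 10000 nM and the earlier step was a 10-fold higher number from compound 2 to compound 1 (1.00 log units; beyond the scatter), compound 4 is expected to show a 3.0-fold higher number from compound 3 to compound 4 (0.48 log units; beyond the scatter). Compound 4 is estimated at 30000 nM, expected between 8000 nM and 150000 nM.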

Compound 4, concentration for 50% growth inhibition: 10000 nM
The estimate for compound 4 lay 3.0-fold (0.48 log units) above the measured number; low and high end bracket the measured number.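

On the core carrying the (4-methylphenyl)sulfonyl group, swapping the chloro for hydrogen in this assay gives no change at the digits printed from compound 3 to compound 4 (within the scatter), so the step seen on the core carrying the (4-methylphenyl)sulfanyl group does not carry over: the same change on two cores in this assay, a 10-fold higher number (1.00 log units; beyond the scatter) from compound 2 to compound 1 and no change at the digits printed (within the scatter) from compound 3 to compound 4, 10-fold (1.00 log units) apart, beyond the scatter of two such steps. Read the other way, the sulfonyl-for-sulfanyl swap on the core without the chloro gives no change at the digits printed from compound 1 to compound 4 (within the scatter), and this too fails to match the same swap on the core with the chloro: the same change on two cores in this assay, a 10-fold higher number (1.00 log units; beyond the scatter) from compound 2 to compound 3 and no change at the digits printed (within the scatter) from compound 1 to compound 4, 10-fold (1.00 log units) apart, beyond the scatter of two such steps. In these four compounds, then, the effect of each change depends on what stands elsewhere in the molecule, but that rests on a single set of four, and it shows neither why this happens nor whether it would hold on any other core.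

As far as these compounds go, it remains open whether a bromo, a methoxy or an amine in the place of the chloro would follow the chloro on each core. Also open, from the compounds shown here alone, is how a (4-methylphenyl)sulfinyl group would behave in the place of the sulfanyl and sulfonyl groups.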